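A few compounds are considered here, and "the series" means these few. Any claim that something is new, unique, unknown or untested is made for them only; others in the source may bear on it.

Compound 2 `Cc1ccc2oc(CSc3nc4ccccc4s3)cc(=O)c2c1` and compound 1 `O=c1cc(CSc2nc3ccccc3s2)oc2ccc(Cl)cc12` share one core and differ in a single place: chloro in place of methyl on an aromatic carbon. In a functional assay on SW480 cells (Homo sapiens) for cytotoxicity, read by MTT assay, with a stated time of 72 h (on this read-out lower numbers stand for stronger inhibition and higher numbers for weaker inhibition), compound 2 reaches only a limit of the assay, > 25000 nM. In this assay compound 1 likewise reaches only a limit, > 25000 nM. The step that the two limits leave unreadable from compound 2 to compound 1 therefore stays unreadable because of the limit of > 25000 nM in this assay, at which 3 of the 3 values shown sit. Compound 3 `Cc1ccc2oc(CSc3nnc(C)s3)cc(=O)c2c1` has another core; the difference between the two cores is not broken down here. In this assay compound 3 again gives only a limit, > 25000 nM. Compound 4 `Cc1nnc(SCc2cc(=O)c3cc(Cl)ccc3o2)s1` follows from compound 3 by the same change, (chloro in place of methyl on an aromatic carbon), at the same place. The expected step that the limit leaves unreadable from compound 3 to compound 4 is estimated to echo the earlier one since the same change gave a step that the two limits leave unreadable from compound 2 to compound 1. For compound 4 the expected value is 40000 nM, estimated to lie between 10000 nM and 150000 nM, most probably again only a limit.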

Compound 4, half-maximal inhibitory concentration: > 25000 nM
Compound 4: a limit, no number; the forecaster's own chance of this, stated with the estimate: 85%; the middle value is on the limit's open side.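

Compound 3 and compound 4 both give only a limit, so no step can be read between them: the limit of > 25000 nM in this assay, at which 4 of the 4 values shown sit.

The compounds shown leave open whether chloro in place of methyl changes cytotoxicity at all in this assay.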